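Swapping a methyl for a tert-butyl on a tolyl ring

The compounds below may be only part of what the source reports. "The series", "measured", "known", "first", "only" and "open" are said of these compounds alone.

Compound 1 `COc1cc(-c2ccnc3cc(-c4ccc(C)cc4)nn23)cc(OC)c1OC` is the starting point of this comparison. Among the compounds with values here, in a functional assay on HeLa cells (Homo sapiens) for inhibition, read by CCK-8 assay, with a stated time of 48 h (a higher number here means a weaker inhibitor, a lower number a stronger inhibitor), compound 1 gives 21 nM, and this is the only number available, since the second result is not a number at all. Compound 2 `COc1ccc(-c2cc3nccc(-c4cc(OC)c(OC)c(OC)c4)n3n2)cc1[N+](=O)[O-]` reaches only a limit of the assay in this assay, at > 10000 nM. In this way compound 1 stands alone, against the limit of > 10000 nM in this assay, at which 1 of the 2 values shown sits, as the sole other entry. Compound 3 `COc1cc(-c2ccnc3cc(-c4ccc(C(C)(C)C)cc4)nn23)cc(OC)c1OC` differs from compound 1 by a single change on the outer ring: tert-butyl in place of methyl on an aromatic carbon. Within the data shown here, no measured pair shows what this kind of change does here, so the size of the expected step rests on compound 1 alone. Compound 3 is expected to be somewhat weaker, with an estimated step from a 2.9-fold higher number from compound 1 to compound 3 (0.46 log units; beyond the scatter), though a result within the scatter would not surprise. The estimate for compound 3 is 60 nM, with a range from 15 nM to 400 nM.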

Compound 3, half-maximal inhibitory concentration: > 10000 nM
Compound 3: only a limit was reported; the forecaster's own chance of this, stated with the estimate: 5%; at least 160-fold (2.22 log units) between middle value and limit.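

Methyl and tert-butyl on the outer ring are far from interchangeable: in this assay the change from 4-methylphenyl to 4-(tert-butyl)phenyl gives an at least 470-fold higher number from compound 1 to compound 3 (2.67 log units; beyond the scatter) and takes away nearly all the measurable effect of compound 1. Only carbon atoms and their hydrogens change in this swap, yet this one place on the outer ring accepts the methyl of compound 1 and not the tert-butyl of compound 3. The result for compound 3 is a limit of the assay and not a number, so the full size of the loss stays unknown: the limit of > 10000 nM in this assay, at which 2 of the 3 values shown sit.

Going by these compounds, whether an ethyl or an isopropyl group at this place would keep the effect of compound 1 remains open. So does the behaviour of a methoxy group or an amine there.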